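The compounds below may be only part of what the source reports. "The series", "measured", "known", "first", "only" and "open" are said of these compounds alone.

Compound 1 `O=c1oc(Nc2ccccc2I)nc2cc(Cl)ccc12` was examined in an assay on isolated protein for inhibition of complement C1r subcomponent (Homo sapiens) (a lower number here means a stronger inhibitor, a higher number a weaker inhibitor), where compound 1 gives 700 nM. Within the data shown here, its only measured neighbour is compound 2 `O=c1oc(Nc2ccccc2I)nc2cc(Cl)c(Cl)cc12`, which carries a further chloro; in this assay compound 2 gives 500 nM. Among the measured compounds shown here, the step of a 1.4-fold lower number from compound 1 to compound 2 (0.15 log units; within the scatter) is the one measured step in this set, and it stays within the scatter. Compound 1 thus stands at the higher of the two numbers, but its gap to compound 2 is not one that can be read as a real difference.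

Compound 3 `COc1ccc2c(=O)oc(Nc3ccccc3I)nc2c1` departs from compound 1 at another point: methoxy in place of chloro on an aromatic carbon. The methoxy enters on an aromatic carbon of a six-membered aromatic ring of carbon only, part of a fused system of two rings. For the measured compounds named here, no measured step swaps one group for another at that carbon, and the only measured change, a 1.4-fold lower number from compound 1 to compound 2 (0.15 log units; within the scatter), concerns an added chloro and lies within the scatter, so it gives no direction for this exchange. A step of no more than the scatter is therefore expected in this assay, with no direction favoured. Compound 3 is estimated at 900 nM, with a range from 300 nM to 2700 nM, an expected step of a 1.3-fold higher number from compound 1 to compound 3 (0.11 log units; within the scatter).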

Compound 3, half-maximal inhibitory concentration: > 62500 nM
Compound 3: a limit, no number; the forecaster's own chance of this, stated with the estimate: 5%; at least 69-fold (1.84 log units) between middle value and limit.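

Among these compounds, this carbon of the shared core proves far less forgiving than the earlier compounds suggested: methoxy in place of chloro, on a carbon meta to a fused ring and para to a fused ring, gives an at least 89-fold higher number from compound 1 to compound 3 (1.95 log units; beyond the scatter). Among the compounds shown here, the only earlier step, a 1.4-fold lower number from compound 1 to compound 2 (0.15 log units; within the scatter), came from an added chloro and said nothing about exchanging the group at this carbon, whereas this single exchange moves compound 3 out of the range of compound 1 and compound 2 in this assay. The reading for compound 3 is a limit and not a number, so the step has a floor but no measured size: the limit of > 62500 nM in this assay, at which 1 of the 3 values shown sits.

The compounds shown leave open whether the step comes from losing the chloro or from gaining the methoxy, a question that hydrogen, fluoro or methyl at this carbon would help to separate. Also open, as far as these compounds go, is how a hydroxy group, an amine or a longer ether such as ethoxy at the same carbon would read in this assay.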